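Swapping Methoxy for Chloro on a Curcumin-like Core

The compounds below may be only part of what the source reports. "The series", "measured", "known", "first", "only" and "open" are said of these compounds alone.

Measured compounds:
Compound 1, `COc1ccc2c(c1)nc(/C=C/C(=O)/C=C/c1ccc(O)c(OC)c1)n2C`, gives 4800 nM in a functional assay on SH-SY5Y cells (Homo sapiens) for cytotoxicity, read by MTT assay, with a stated time of 48 h; on this read-out higher numbers stand for weaker inhibition and lower numbers for stronger inhibition.
Compound 2, `COc1cc(/C=C/C(=O)/C=C/c2nc3cc(Cl)ccc3n2C)ccc1O`, gives 4700 nM in this assay.
Compound 3, `COc1ccc2c(c1)nc(/C=C/C(=O)/C=C/c1ccc(OC)c(O)c1)n2C`, gives 4800 nM in this assay.

Compounds 1 and 3 share the same atoms joined differently: 3-hydroxy-4-methoxyphenyl in place of 4-hydroxy-3-methoxyphenyl on a double-bonded chain carbon bound to a double-bonded chain carbon. Their values sit level, so no order can be read between them. Compound 2 arises from compound 1 by chloro in place of methoxy on an aromatic carbon, and that step is a 1.0-fold lower number from compound 1 to compound 2 (0.01 log units; within the scatter).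

Compound 4, `COc1ccc(/C=C/C(=O)/C=C/c2nc3cc(Cl)ccc3n2C)cc1O`, is not yet measured. It arises from compound 3 by chloro in place of methoxy on an aromatic carbon, the same change at the same place as between compound 1 and compound 2. Because a 1.0-fold lower number from compound 1 to compound 2 (0.01 log units; within the scatter) stayed within the scatter, a step of similar size is expected here, a 1.0-fold lower number from compound 3 to compound 4 (0.01 log units; within the scatter). Compound 4 is therefore estimated at 4700 nM, with a likely range from 2400 nM to 9400 nM.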

Compound 4, half-maximal inhibitory concentration: 4800 nM
Compound 4: middle estimate off by 1.0-fold (0.01 log units), on the low side; the range from low to high includes it.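

In this assay, chloro in place of methoxy on the core carrying the 3-hydroxy-4-methoxyphenyl group gives no change at the digits printed from compound 3 to compound 4 (within the scatter). Set beside the earlier step, the swap reads the same on both cores: the same change on two cores in this assay, a 1.0-fold lower number (0.01 log units; within the scatter) from compound 1 to compound 2 and no change at the digits printed (within the scatter) from compound 3 to compound 4, 1.0-fold (0.01 log units) apart, within the scatter of two such steps This shows that the swap left the number within the scatter on both cores, but it does not show that a step of visible size would carry over, or that the result would hold on a core that differs more widely.

As far as these compounds go, only methoxy and chloro appear on this aromatic carbon, so the effect of an amine or a carboxylic acid there remains open. Also open, from the compounds shown here alone, is whether a longer chain in that place would shift the value.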